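The source may report more compounds than this note shows. Statements on the series, on what has been measured and on what is new or still open speak of the compounds shown alone.

In a functional assay on MDA-MB-231 cells (Homo sapiens) for antiproliferative activity, read by MTT assay, with a stated time of 72 h (a lower number here means a stronger inhibitor, a higher number a weaker inhibitor), compound 1 `CSCCc1nc(-c2cccc(N)c2)oc1C` gives 1.33 nM and compound 2 `CSCCc1nc(-c2cc(N)ccc2Cl)oc1C` gives 1.2 nM. Among the measured compounds shown here, compound 1 therefore stands level with compound 2, the only other compound measured so far. For the measured compounds named here, the single measured step, chloro in place of hydrogen on an aromatic carbon, is a 1.1-fold lower number from compound 1 to compound 2 (0.04 log units; within the scatter). Compound 3 `CSCCc1nc(-c2cccc(NC(=N)N)c2)oc1C` keeps the core of compound 1 and differs by a group of 3 heavy atoms (1 carbon, 2 nitrogen; no ring) in place of a hydrogen atom, on a nitrogen on an aromatic ring. Going by the values given here, the measured step bears on this change only loosely, as it involves an aromatic carbon and no measured step involves that nitrogen. Its small size therefore cannot show that compound 3 will stay level, and a moderate shift towards a higher number in this assay is expected, with wide uncertainty. The expected step is a 3.0-fold higher number from compound 1 to compound 3 (0.48 log units; beyond the scatter). Compound 3 is estimated at 4 nM, with an expected range of 0.7 nM to 30 nM.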

Compound 3, half-maximal inhibitory concentration: 1.33 nM
The estimate for compound 3 lay 3.0-fold (0.48 log units) above the measured number, within the range that was stated.
By their numbers in this assay, from the lowest: compounds 2, 1 and 3 (each within the scatter of the next).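

Among the compounds shown here, the nitrogen on the aromatic ring, which no earlier step had touched, now shows no change at the digits printed from compound 1 to compound 3 (within the scatter) in this assay when it takes a group of 3 heavy atoms (1 carbon, 2 nitrogen; no ring) in place of a hydrogen atom. On this single change, a group with 2 hydrogen-bond donors and 1 double bond outside aromatic rings can stand on that nitrogen without a shift beyond the scatter, so both steps now read from compound 1 lie within it. Nothing measured here speaks to what lies behind this result.

The compounds shown leave open whether an acetyl group or a longer chain such as butyl on that nitrogen would also keep the number level. They also leave open whether the same group keeps it level when chloro stands on the aromatic carbon, as in compound 2.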